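A few compounds are considered here, and "the series" means these few. Any claim that something is new, unique, unknown or untested is made for them only; others in the source may bear on it.

Compound 1 `CCCCNC(=O)C(=O)C(CCC)NC(=O)[C@@H]1[C@@H]2[C@H](CN1C(=O)[C@@H](NC(=O)OC(C)(C)C)C1CCCCC1)C2(C)C`: "not determined" (no result reported)
Compound 2 `CCCC(NC(=O)[C@@H]1[C@@H]2[C@H](CN1C(=O)[C@@H](NC(=O)OC(C)(C)C)C1CCCCC1)C2(C)C)C(=O)C(=O)NC`: 7160 ng.h/mL

Within the data shown here, in an ADME assay on the whole organism (plasma) for pharmacokinetics, with Rattus norvegicus as the target, with a stated time of 6 h, at a dose of 10 mg by the oral route (a higher number here means more compound in the circulation at the dose given, a lower number less compound in the circulation), compound 2 gives 7160 ng.h/mL, the only number available, so it has no rank against another compound. Compound 3 `CCCC(NC(=O)[C@@H]1[C@@H]2[C@H](CN1C(=O)[C@@H](NC(=O)OC(C)(C)C)C1CCCCC1)C2(C)C)C(=O)C(N)=O` carries one change from compound 2: hydrogen in place of methyl on an amide-type nitrogen. Among the measured compounds shown here, no measured step shows what this change does in this assay, so the expectation rests only on compound 2 at 7160 ng.h/mL and remains loose. A moderate fall is expected, with the estimated step of a 2.4-fold lower number from compound 2 to compound 3 (0.38 log units; beyond the scatter). For compound 3 the expected value is 3000 ng.h/mL, within an estimated range of 800 ng.h/mL to 9000 ng.h/mL.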

Compound 3, area under the concentration-time curve: 1310 ng.h/mL
For compound 3 the middle estimate is 2.3-fold (0.36 log units) above the measured one; measured number inside the range.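

In this assay, among these compounds, the change from methylcarbamoyl to carbamoyl gives a 5.5-fold lower number from compound 2 to compound 3 (0.74 log units; beyond the scatter) and so provides the first reading at this position. On the amide-type nitrogen, methyl stands on the higher side of the step and hydrogen on the lower side in this pair. No measured evidence here accounts for the step. On these data alone, how an ethyl or a cyclopropyl on that nitrogen would read remains open. As far as these compounds go, whether the same step holds with another group in place of the tert-butyl carbamate also remains open.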